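Cyano in place of methoxy on compound 2

The source may hold more compounds than are shown below. What is called first, only, known or untested is meant among the compounds shown, and "the series" means these compounds.

Compound 1 `Cc1nn(-c2ccccn2)c2cc(-c3ccc(CCC(=O)O)cc3)ncc12` gives 1.6
Compound 2 `COc1cc(CCC(=O)O)ccc1-c1ccc2c(C)nn(-c3ccccn3)c2c1` gives 2.4

In a physicochemical assay for lipophilicity, using the shake flask method, measured as octanol-water partition, with a stated time of 30 min, at pH 7.4 (on this read-out higher numbers stand for higher lipophilicity and lower numbers for lower lipophilicity), compound 2 gives 2.4 and stands highest of the two, with a gap to compound 1 that lies beyond the scatter. Compound 3 `Cc1nn(-c2ccccn2)c2cc(-c3ccc(CCC(=O)O)cc3C#N)ccc12` differs from compound 2 in one place: cyano in place of methoxy on an aromatic carbon, ortho to a large group (cyano in place of methoxy on an aromatic carbon). Within the data shown here, no measured pair shows this swap, so the expectation rests on the structural change alone. A modest fall, estimated as a number 0.40 log units lower from compound 2 to compound 3 (beyond the scatter) and so slightly beyond the scatter, is expected. For compound 3 the estimated value is 2 (range 1.6 to 2.4).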

Compound 3, distribution coefficient: 2.2
The estimate for compound 3 lay 0.20 log units below the measured number, within the range that was stated.
By their numbers in this assay, from the lowest: compound 1; then compounds 3 and 2 (each within the scatter of the next).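

In this assay, cyano in place of methoxy on an aromatic carbon, ortho to a large group, gives a number 0.20 log units lower from compound 2 to compound 3 (within the scatter), so on this read-out the two groups cannot be told apart at this position. The pair also shares a count of heavy atoms and of hydrogen-bond acceptors, yet no measurement here gives a reason for the result. As far as these compounds go, whether an amine or a longer chain on this same carbon would also stay within the scatter of methoxy remains open. So does whether this swap would give a similar step on the core of compound 1.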